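Notes on a second methoxy addition in this series

The source may report more compounds than this note shows. Statements on the series, on what has been measured and on what is new or still open speak of the compounds shown alone.

Of the compounds shown here, three have been tested in a functional assay on MCF7 cells (Homo sapiens) for cytotoxicity, read by sulforhodamine B assay, with a stated time of 48 h, tested at 1 uM; a lower number here means a stronger effect, a higher number a weaker effect of the compound at the concentration tested. Compound 1 `COc1ccc(-c2cc(/C=C/C(=O)c3ccc(N)cc3)[nH]n2)cc1` gives 42%, compound 3 `COc1ccc(-c2cc(/C=C/C(=O)c3ccc(N)cc3)[nH]n2)cc1OC` gives 81%, and compound 2 `COc1ccc(C(=O)/C=C/c2cc(-c3cc(OC)c(OC)c(OC)c3)n[nH]2)cc1OC` gives 31%. Compound 2 stands lowest of the three, with compound 1 nearest and compound 3 furthest. The difference between the cores of compound 1 and compound 2 is not broken down here.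

Compound 3 differs from compound 1 by methoxy in place of hydrogen on an aromatic carbon. In this assay that change made a step of a number 39 percentage points higher from compound 1 to compound 3 (beyond the scatter).

Compound 4 `COc1cc(C(=O)/C=C/c2cc(-c3cc(OC)c(OC)c(OC)c3)n[nH]2)cc(OC)c1OC` has not yet been measured; it differs from compound 2 by methoxy in place of hydrogen on an aromatic carbon. This is the same kind of change as from compound 1 to compound 3, with one difference around the place: in compound 4 the entering methoxy is also meta to a methoxy group. For the measured compounds named here, only that one measured step exists to rest on, so the step is expected to go the same way, since the earlier change gave a number 39 percentage points higher from compound 1 to compound 3 (beyond the scatter). The expected step is a number 27 percentage points higher from compound 2 to compound 4 (beyond the scatter). For compound 4 the estimate in this assay is 58%, expected to lie between 32% and 85%.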

Compound 4, a percentage reported as activity, at one concentration (the size of the read-out at that concentration, not a potency): 40%
For compound 4 the middle estimate is 18 percentage points above the measured one, and the stated range covers the measured number.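

For the compounds shown here, the same methoxy addition on the core of compound 2 gave, in this assay, a number 9 percentage points higher from compound 2 to compound 4 (within the scatter), so on this core the change produced no step that stands out from the scatter. Set beside the earlier step, the change did not carry its size over from one core to the other: the same change on two cores in this assay, a number 39 percentage points higher (beyond the scatter) from compound 1 to compound 3 and a number 9 percentage points higher (within the scatter) from compound 2 to compound 4, 30 percentage points apart, beyond the scatter of two such steps

This rests on a single pair per core, and in compound 4 the entering methoxy is also meta to a methoxy group, so the data cannot separate that difference of place from the rest of the core, and they say nothing about how the change would behave on a further core.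

From the compounds shown here alone, whether a hydroxyl group or a chlorine atom in place of hydrogen at these positions would follow either step remains open. Each number is also a read-out at one concentration, so the two pairs can be compared only as a stronger or weaker effect at that concentration.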